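From Dihydroxypropyl to Cyclopropyl on the Amide Nitrogen

The compounds below may be only part of what the source reports. "The series", "measured", "known", "first", "only" and "open" are said of these compounds alone.

Compound 1 `Cn1ncc(Cl)c1-c1cc(C(=O)N[C@@H]2CN[C@H](CCn3cncn3)C[C@H]2c2ccc(Cl)c(Cl)c2)oc1Cl`: 1560 nM
Compound 2 `C=CC[C@@H]1C[C@@H](c2ccc(Cl)c(Cl)c2)[C@H](NC(=O)c2cc(-c3c(Cl)cnn3C)c(Cl)o2)CN1`: 990 nM
Compound 3 `Cn1ncc(Cl)c1-c1cc(C(=O)N[C@@H]2CN[C@H](CC(=O)NCC(O)CO)C[C@H]2c2ccc(Cl)c(Cl)c2)oc1Cl`: 5900 nM

In a functional assay on OVCAR-8 cells (Homo sapiens) for antiproliferative activity (on this read-out lower numbers stand for stronger inhibition and higher numbers for weaker inhibition), compound 3 has the highest number of the three, 5900 nM, making it the weakest one measured. Compound 4 `Cn1ncc(Cl)c1-c1cc(C(=O)N[C@@H]2CN[C@H](CC(=O)NC3CC3)C[C@H]2c2ccc(Cl)c(Cl)c2)oc1Cl` differs from it in one place, with cyclopropyl in place of 2,3-dihydroxypropyl on an amide-type nitrogen. For the measured compounds named here, no measured step makes exactly this change. The closest evidence is that introducing (2,3-dihydroxypropyl)carbamoyl raised the number, in a 3.8-fold higher number from compound 1 to compound 3 (0.58 log units; beyond the scatter) and in a 6.0-fold higher number from compound 2 to compound 3 (0.78 log units; beyond the scatter), while a 1.6-fold lower number from compound 1 to compound 2 (0.20 log units; within the scatter) stays within the scatter. A modest drop is therefore expected in this assay, an estimated 3.0-fold lower number from compound 3 to compound 4 (0.47 log units; beyond the scatter). For compound 4 the estimated value is 2000 nM, with an expected range of 800 nM to 5000 nM.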

Compound 4, half-maximal inhibitory concentration: 580 nM
Beside the measured number, compound 4's estimate is 3.4-fold (0.54 log units) above it; measured number outside the range, below it.
By their numbers in this assay, from the lowest: compounds 4, 2 and 1 (each within the scatter of the next, the first and the last beyond it); then compound 3.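

In this assay, replacing 2,3-dihydroxypropyl with cyclopropyl on the amide-type nitrogen gives a 10-fold lower number from compound 3 to compound 4 (1.01 log units; beyond the scatter), so the earlier rise in compound 3 belongs to that substituent and not to the carbamoyl alone. With cyclopropyl, the carbamoyl chain matches the vinyl of compound 2, a 1.7-fold lower number from compound 2 to compound 4 (0.23 log units; within the scatter), and improves on the triazolylmethyl of compound 1, a 2.7-fold lower number from compound 1 to compound 4 (0.43 log units; beyond the scatter). No measurement here gives a reason for these steps.

The compounds shown leave open whether the gain comes from the ring or from losing the hydroxyl groups. A plain propyl on this nitrogen would help separate the two.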